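Cyclohexyl for phenyl alongside the 4-fluorophenyl group

A few compounds are considered here, and "the series" means these few. Any claim that something is new, unique, unknown or untested is made for them only; others in the source may bear on it.

Of the compounds shown here, two have values so far in a functional assay on FM3A cells (Mus musculus) for cytotoxicity (a higher number here means that more compound is needed for the effect, a lower number that less compound is needed), and they sit close together. There compound 1 `c1ccc(C23CCCC(OOC(C4CCCCC4)OO2)O3)cc1` gives 10000 nM and compound 2 `Fc1ccc(C23CCCC(OOC(c4ccccc4)OO2)O3)cc1` gives 8100 nM as its half-maximal effective concentration. The two numbers lie within the scatter of each other, so compound 2 stands level with compound 1 on the present data.

Compound 3 `Fc1ccc(C23CCCC(OOC(C4CCCCC4)OO2)O3)cc1` follows from compound 2 with cyclohexyl in place of phenyl on a saturated ring carbon, between two ring oxygen atoms. The counted change is cyclohexyl in place of phenyl on a saturated ring carbon and the 4-fluorophenyl group stays where it is.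

For the measured compounds named here, no measured pair shows this change alone, so the step has no direct precedent in this assay yet. With compound 1 at 10000 nM and compound 2 at 8100 nM not separated beyond the scatter, no step beyond the scatter is expected in either direction. The estimated change is a 1.1-fold higher number from compound 2 to compound 3 (0.05 log units; within the scatter) and would stay inside the scatter. For compound 3 the expected value is 9000 nM with an estimated range from 4000 nM to 20000 nM in this measurement.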

Compound 3, half-maximal effective concentration: 2500 nM
For compound 3 the middle estimate is 3.6-fold (0.56 log units) above the measured one; the measured number lies below the stated range.
By their numbers in this assay, from the lowest: compound 3; then compounds 2 and 1 (each within the scatter of the next).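

With cyclohexyl on the saturated ring carbon between two ring oxygen atoms, the series now shows a real difference in this assay: there is a 3.2-fold lower number from compound 2 to compound 3 (0.51 log units; beyond the scatter) while the 4-fluorophenyl group stays in place. Keeping cyclohexyl at that carbon and placing fluoro instead of hydrogen on an aromatic carbon gives a 4.0-fold lower number from compound 1 to compound 3 (0.60 log units; beyond the scatter) as a second single-place step, so compound 3 is separated from both earlier compounds by steps beyond the scatter. Compounds 1 and 2 differ in two places, so their pairing could not isolate either change, whereas these two steps each isolate one change and both end at compound 3.

Open, from the compounds shown here alone, is whether a hexyl chain on the same ring carbon would match cyclohexyl, which would show whether the ring itself matters at this position. Also open, going by these compounds, is whether the fluoro step would recur with phenyl in place of cyclohexyl, since it has so far been read only with cyclohexyl present. No supporting data are available to explain either step.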